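The compounds below may be only part of what the source reports. "The series", "measured", "known", "first", "only" and "open" are said of these compounds alone.

Compound 1 `COc1ccccc1/C=C(/Sc1ccc(C)cc1)C(=O)c1ccc(Cl)cc1`: 25000 nM
Compound 2 `Cc1ccc(S/C(=C/c2ccc(N(C)C)cc2)C(=O)c2ccc(Cl)cc2)cc1`: > 100000 nM (a limit of the assay, not a number)

In a functional assay on DU-145 cells (Homo sapiens) for inhibition, read by trypan blue exclusion, with a stated time of 96 h (on this read-out lower numbers stand for stronger inhibition of growth and higher numbers for weaker inhibition of growth), compound 2 sits at the limit of > 100000 nM in this assay, at which 1 of the 2 values shown sits, the weak end of what is shown. Compound 3 `COc1ccc(/C=C(/Sc2ccc(C)cc2)C(=O)c2ccc(Cl)cc2)cc1` differs from it in one place: methoxy in place of dimethylamino on an aromatic carbon. For the measured compounds named here, the only measured step that bears on this is an at least 4.0-fold higher number from compound 1 to compound 2 (0.60 log units; beyond the scatter), where the methoxy-bearing compound gave the lower number, although there the group was 2-methoxyphenyl rather than 4-methoxyphenyl. A step of roughly that size back toward stronger inhibition is therefore expected, an at least 2.5-fold lower number from compound 2 to compound 3 (0.39 log units; beyond the scatter). Compound 3 is expected to give about 40000 nM, within 12000 nM to 120000 nM.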

Compound 3, concentration for 50% growth inhibition: 1000 nM
For compound 3 the middle estimate is 40-fold (1.60 log units) above the measured one, and the stated range ends above it.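

In this assay, there is an at least 100-fold lower number from compound 2 to compound 3 (2.00 log units; beyond the scatter) when methoxy replaces dimethylamino, so the group at this spot, para to a large group, can shift growth inhibition a long way. As far as these compounds go, the real size of that step stays unknown because compound 2 gives only a limit of the assay, not a number: the limit of > 100000 nM in this assay, at which 1 of the 3 values shown sits. Moving the methoxy also matters, with 4-methoxyphenyl in place of 2-methoxyphenyl giving a 25-fold lower number from compound 1 to compound 3 (1.40 log units; beyond the scatter). From the compounds shown here alone, whether ethoxy, hydroxy or a plain amine on this carbon would match methoxy stays open.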